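Swapping the aryl group on a shared triazine core

The source may report more compounds than this note shows. Statements on the series, on what has been measured and on what is new or still open speak of the compounds shown alone.

Measured so far:
compound 1 `NC1=NC2(CCSCC2)N(OCCCOc2ccc(Br)cc2)C(N)=N1` — 350 nM
compound 2 `NC1=NC2(CCOCC2)N(OCCCOc2ccccc2Cl)C(N)=N1` — 660 nM
compound 3 `NC1=NC2(CCSCC2)N(OCCCOc2cc(Cl)c(Cl)cc2Cl)C(N)=N1` — 730 nM

All three were tested in a functional assay on HL-60 cells (Homo sapiens) for antiproliferative activity, read by MTT assay, with a stated time of 72 h; on this read-out higher numbers stand for weaker inhibition and lower numbers for stronger inhibition. Among these three numbers compound 2, with 660 nM, stands second highest: compound 3 sits closest to it and compound 1 furthest, but both of those gaps are within the scatter, so the three compounds cannot be ranked against each other.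

Compound 4 `Cc1ccc(OCCCON2C(N)=NC(N)=NC23CCOCC3)cc1` is not yet measured. It differs from compound 2 in one place: 4-methylphenyl in place of 2-chlorophenyl on an oxygen on a saturated carbon. Going by the values given here, the only measured step that touches the same part of the molecule is a 2.1-fold higher number from compound 1 to compound 3 (0.32 log units; beyond the scatter), a modest shift in the thiane-bearing series. Among the compounds with values here, no measured step shows the effect of 4-methylphenyl entering for 2-chlorophenyl on the oxane-bearing core, so that step carries only a loose guide.

The step from compound 2 to compound 4 is therefore expected to be small, a 1.1-fold higher number from compound 2 to compound 4 (0.03 log units; within the scatter), with no clear direction beyond the scatter. Compound 4 is expected to give 700 nM, within a range from 300 nM to 1600 nM.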

Compound 4, half-maximal inhibitory concentration: 2580 nM
The estimate for compound 4 lay 3.7-fold (0.57 log units) below the measured number; the measured number lies above the stated range.
By their numbers in this assay, from the lowest: compounds 1, 2 and 3 (each within the scatter of the next, the first and the last beyond it); then compound 4.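

In this assay, 4-methylphenyl in place of 2-chlorophenyl gives a 3.9-fold higher number from compound 2 to compound 4 (0.59 log units; beyond the scatter), so on this shared core the choice of aryl group can move the number beyond the scatter. The two groups have the same number of heavy atoms, one aromatic ring of carbon only, no hydrogen-bond donors or acceptors and no net charge, so these counts do not separate them even though the number changes. Nothing available explains this shift.

This single step changes both the substituent and its number on the ring, so it cannot show whether losing the chlorine, gaining the methyl or the different placement matters most. Open too, on these data alone, is how an unsubstituted phenyl group, or a longer chain in this part of the molecule, would behave.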